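The compounds below may be only part of what the source reports. "The series", "measured", "known", "first", "only" and "open" are said of these compounds alone.

Series notes. Three compounds share one core: compound 1 `CC(C)c1ccc(NCN2C(=O)c3ccccc3C2=O)cc1`, compound 2 `COc1ccc(NCN2C(=O)c3ccccc3C2=O)cc1` and compound 3 `O=C1c2ccccc2C(=O)N1CNc1ccc(OC(F)(F)F)cc1`. Among the compounds with values here, in an assay on isolated protein for inhibition of ribosomal protein S6 kinase alpha-2 (Homo sapiens), read by fluorescence, with a stated time of 20 min (on this read-out lower numbers stand for stronger inhibition and higher numbers for weaker inhibition), compound 2 gives 470 nM; for compound 1 the entry is "not determined" (no result reported) and for compound 3 the entry is "not determined" (no result reported), so compound 2 stands alone as the only number in this set, with nothing to rank it against. Compound 4 `COc1ccc(NCN2C(=O)c3cccc(N)c3C2=O)cc1` is not yet measured. It differs from compound 2 in one place: amino in place of hydrogen on an aromatic carbon. Within the data shown here, no measured pair shows this change, so nothing here sets its size. The expected step of a 1.2-fold lower number from compound 2 to compound 4 (0.07 log units; within the scatter) is accordingly small, with no clear direction and not beyond the scatter. Compound 4 is estimated at 400 nM, with a range from 120 nM to 1500 nM.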

Compound 4, half-maximal inhibitory concentration: 3530 nM
Compound 4: the middle estimate sits 8.8-fold (0.95 log units) below what was measured, and the stated range ends below it.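

In this assay amino in place of hydrogen on an aromatic carbon, ortho to a fused ring and meta to a fused ring, gives a 7.5-fold higher number from compound 2 to compound 4 (0.88 log units; beyond the scatter), a loss of inhibition beyond the usual scatter. Within the data shown here, this carbon of the shared core is therefore sensitive to substitution, and this change costs inhibition, which the earlier compounds could not show. On these data alone, whether a hydroxyl, a methyl or a fluorine at this carbon costs as much remains open, as does the same change on the core of compound 1. Nothing shown bears on the cause of this step.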